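Replacing the Furan-3-yl Group of Compound 1

This account rests on a few compounds, and the source may have more. Where it says the series, first, only, none or still open, it means among the compounds named here.

Of the compounds shown here, three built on one shared core have been tested in a functional assay on A549 cells (Homo sapiens) for antiproliferative activity, read by XTT assay, with a stated time of 72 h; on this read-out higher numbers stand for weaker inhibition and lower numbers for stronger inhibition. Compound 1 `C=C(C)CCC[C@]1(C)C2=CCC[C@](C)(C[C@@H](O)c3ccoc3)[C@H]2CC[C@H]1C` gives 66000 nM in this assay, the highest of the three numbers. For the measured compounds named here, compound 2 `C=C(C)CC[C@]1(C)C2=CCC[C@](C)(C[C@@H](O)c3ccoc3)[C@H]2CC[C@H]1C` gives 34000 nM, and the single change between the two produced a 1.9-fold lower number from compound 1 to compound 2 (0.29 log units; within the scatter). Going by the values given here, compound 3 `C=C(C)CC[C@]1(C)C2=CCC[C@](C)(C[C@@H](OC(C)=O)C3=CC(=O)OC3O)[C@H]2CC[C@H]1C` gives 11100 nM; it differs from compound 2 in two places at once, so its number shows only that both changes together went with a lower value.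

Compound 4 `C=C(C)CCC[C@]1(C)C2=CCC[C@](C)(C[C@@H](O)C3=CC(=O)OC3O)[C@H]2CC[C@H]1C` has not yet been measured. It differs from compound 1 in one place: a group of 7 heavy atoms (4 carbon, 3 oxygen; one five-membered non-aromatic ring with 1 hetero atom) in place of a group of 5 heavy atoms (4 carbon, 1 oxygen; one five-membered aromatic ring with 1 hetero atom), on a saturated chain carbon bound to an oxygen on a saturated carbon and a saturated chain carbon. Among the compounds with values here, no measured step isolates this change. The closest evidence is compound 3, which carries the same entering group together with an acetyl and gives 11100 nM, while compound 2 gives 34000 nM. Since that gap rests on two changes, only a moderate step toward a lower number is expected, a 2.4-fold lower number from compound 1 to compound 4 (0.37 log units; beyond the scatter), and it may not exceed the scatter. Compound 4 is therefore estimated at 28000 nM, with an expected range from 9000 nM to 80000 nM.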

Compound 4, half-maximal inhibitory concentration: 3800 nM
Compound 4: the middle estimate sits 7.4-fold (0.87 log units) above what was measured; the whole stated range lies above it.
By their numbers in this assay, from the lowest: compound 4; then compound 3; then compounds 2 and 1 (each within the scatter of the next).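

In this assay, the ring that enters in place of furan-3-yl brings a 17-fold lower number from compound 1 to compound 4 (1.24 log units; beyond the scatter) and lies beyond the scatter, so the group on this saturated chain carbon has a large bearing on the number. The only earlier single change, in the side chain, gave a 1.9-fold lower number from compound 1 to compound 2 (0.29 log units; within the scatter) and stayed within the scatter, so this position is the one shown to move the read-out clearly. Nothing measured here explains why the entering ring lowers the number so much.

The compounds shown leave open whether the hydroxyl or the carbonyl of the entering ring accounts for the step, and whether another group at this position, such as a carboxylic acid or an amine, would lower the number further. They also leave open whether the same replacement on compound 2 would give a step of similar size.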